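Swapping the group on the sulfur chain of compound 1

The source may hold more compounds than are shown below. What is called first, only, known or untested is meant among the compounds shown, and "the series" means these compounds.

compound 1 `COc1ccc(-n2c(SCc3ccc(C)cc3)nnc2-c2cc(OC)c(OC)c(OC)c2)cc1` gives 33300 nM as its value
compound 2 `COc1ccc(CSc2nnc(-c3cc(OC)c(OC)c(OC)c3)n2-c2ccc(OC)cc2)cc1` gives 49600 nM as its value
compound 3 `COc1ccc(-n2c(SCC(=O)c3ccccc3)nnc2-c2cc(OC)c(OC)c(OC)c2)cc1` gives > 60000 nM as a limit of the assay, not a number

Among the measured compounds shown here, in a functional assay on HCT-116 cells (Homo sapiens) for inhibition, read by MTT assay, with a stated time of 48 h (a lower number here means a stronger inhibitor, a higher number a weaker inhibitor), compound 1 and compound 2 hold the only exact numbers, and they sit close together (a 1.5-fold higher number from compound 1 to compound 2 (0.17 log units; within the scatter)). Compound 4 `COc1ccc(C(=O)CSc2nnc(-c3cc(OC)c(OC)c(OC)c3)n2-c2ccc(OC)cc2)cc1` differs from compound 1 by (4-methoxyphenyl)carbonyl in place of 4-methylphenyl on a saturated chain carbon bound to a sulfur. Compound 3 is the nearest guide, since it also carries a carbonyl there (an at least 1.8-fold higher number from compound 1 to compound 3 (0.25 log units; that floor lies within the scatter)). The methoxy of compound 2 adds little (a 1.5-fold higher number from compound 1 to compound 2 (0.17 log units; within the scatter)). A small step to a higher number is expected, the estimated change being a 1.8-fold higher number from compound 1 to compound 4 (0.26 log units; within the scatter) in this assay overall. The estimate for compound 4 is 60000 nM with an expected range from 30000 nM to 120000 nM and a real chance of only a limit.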

Compound 4, half-maximal inhibitory concentration: > 60000 nM
Compound 4 ended at the assay's limit; the forecaster's own chance of this, stated with the estimate: 55%; the middle value lies on the limit itself.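

Compound 4 shows that with (4-methoxyphenyl)carbonyl on this saturated chain carbon bound to a sulfur, the result in this assay is again a limit of the assay, so adding a methoxy to the benzoyl of compound 3 brings back no exact number. Against the two exact values, the result reads as an at least 1.8-fold higher number from compound 1 to compound 4 (0.25 log units; that floor lies within the scatter) and an at least 1.2-fold higher number from compound 2 to compound 4 (0.08 log units; that floor lies within the scatter). The step from compound 3 to compound 4 cannot be read, as both compounds are limits: the limit of > 60000 nM in this assay, at which 2 of the 4 values shown sit.

Going by these compounds, the true values of compound 3 and compound 4 stay open. So does whether an amine or a carboxylic acid in place of 4-methylphenyl on this carbon would give an exact number.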